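Benzothiazolyl for methoxycarbonyl on the shared core: cytotoxicity notes

The source may report more compounds than this note shows. Statements on the series, on what has been measured and on what is new or still open speak of the compounds shown alone.

Compound 1, `COC(=O)c1ccc(NCc2cncn2Cc2ccc(Cl)cc2)cc1-c1ccccc1`: in a toxicity assay on NIH3T3 cells (Mus musculus) for cytotoxicity, read by resazurin assay (a lower number here means that less compound is needed, a higher number that more compound is needed for the effect), compound 1 gives 25000 nM.
Compound 2, `COC(=O)c1ccc(NCc2cncn2Cc2ccc(-c3ccccc3)cc2)cc1-c1ccccc1`: in this assay compound 2 gives only a limit, > 1000 nM.
Compound 3, `COC(=O)c1ccc(NCc2cncn2Cc2cccc([N+](=O)[O-])c2)cc1-c1ccccc1`: in this assay compound 3 gives only a limit, > 10000 nM.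

Among the measured compounds shown here, compound 2 thus stands at a limit, with compound 1 the sole number in the set. The steps a step that the limit leaves unreadable from compound 1 to compound 2 and a step that the limit leaves unreadable from compound 1 to compound 3 cannot be sized because the limit of > 1000 nM in this assay, at which 1 of the 3 values shown sits, and the limit of > 10000 nM in this assay, at which 1 of the 3 values shown sits, hide their end points. Compound 4, `c1ccc(-c2ccc(Cn3cncc3CNc3ccc(-c4nc5ccccc5s4)c(-c4ccccc4)c3)cc2)cc1`, carries the change (1,3-benzothiazol-2-yl in place of methoxycarbonyl on an aromatic carbon). No readable step bears on this change, so the step that the limit leaves unreadable from compound 2 to compound 4 is expected to stay within scatter of compound 2. Compound 4 is therefore estimated at 8000 nM, range 1500 nM to 40000 nM, a limit being likely.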

Compound 4, half-maximal effective concentration: > 1000 nM
Compound 4: no number, only a limit; the forecaster's own chance of this, stated with the estimate: 55%; the middle value is on the limit's open side.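

Compound 2 and compound 4 both give only a limit in this assay, so no step can be read between them: the limit of > 1000 nM in this assay, at which 2 of the 4 values shown sit.

The compounds shown leave open how far 1,3-benzothiazol-2-yl in place of methoxycarbonyl shifts cytotoxicity, and in which direction.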